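Swapping methyl for chloro on the thiazole of compound 3

The source may report more compounds than this note shows. Statements on the series, on what has been measured and on what is new or still open speak of the compounds shown alone.

Of the compounds shown here, three sharing a common amide core have been measured in an assay on CHO cells for displacement of a labelled ligand from adenosine receptor A1 (Homo sapiens), read by scintillation counting, with a stated time of 30 min; on this read-out higher numbers stand for weaker inhibition and lower numbers for stronger inhibition. Compound 1 `COc1c(C(=O)Nc2nccs2)ccc(NC(=O)CC(C)(C)C)c1F` gives 220 nM, and compound 2 `COc1cc(C(=O)Nc2nccs2)ccc1NC(=O)CC(C)(C)C` gives 340 nM. Among the measured compounds shown here, compound 3 `Cc1cnc(NC(=O)c2ccc(NC(=O)CC(C)(C)C)cc2)s1` gives 1100 nM, the highest of the three numbers: compound 2 sits closest to it, and compound 1 furthest, with both gaps beyond the usual scatter, so compound 3 is the weakest inhibitor among the three measured so far.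

Compound 4 `CC(C)(C)CC(=O)Nc1ccc(C(=O)Nc2ncc(Cl)s2)cc1` has not yet been measured. It differs from compound 3 in one place: chloro in place of methyl on an aromatic carbon. For the measured compounds named here, no pair of the measured compounds differs in just this one place, so the data give no direct reading of what such a swap does. For compound 4 a modest change is expected, leaning toward a slightly stronger inhibitor, with the step of a 1.4-fold lower number from compound 3 to compound 4 (0.14 log units; within the scatter) likely to stay near or just beyond the scatter. The estimate for compound 4 in this assay is 800 nM, within a range from 300 nM to 2500 nM.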

Compound 4, inhibition constant: 220 nM
Compound 4: middle estimate off by 3.6-fold (0.56 log units), on the high side, and the stated range ends above it.
By their numbers in this assay, from the lowest: compounds 1, 4 and 2 (each within the scatter of the next); then compound 3.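

In this assay, among the compounds shown here, the change from 5-methyl-1,3-thiazol-2-yl to 5-chloro-1,3-thiazol-2-yl gives a 5.0-fold lower number from compound 3 to compound 4 (0.70 log units; beyond the scatter), the first direct reading of a change at this position. The spot next to the ring sulfur is therefore sensitive to what it carries: exchanging one heavy atom for another, with no hydrogen-bond donors or acceptors on either side, moves the number beyond the scatter and toward stronger inhibition. No measurement available here explains why this swap has this effect.

On these data alone, whether a bromo group, a nitrile or an amine at this position would give a lower or a higher number remains open. So does whether chloro would produce a similar step if placed on the thiazole of compound 1 or compound 2, which carry other changes on the shared core.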